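The source may hold more compounds than are shown below. What is called first, only, known or untested is meant among the compounds shown, and "the series" means these compounds.

Measured compounds in this assay:
compound 1, `Fc1cccc(F)c1Cc1cnc(Nc2ccc(CCOc3ccncc3)cc2)o1`: 11000 nM
compound 2, `Fc1cccc(F)c1Cc1cnc(Nc2ccc(Oc3cccnc3)c(Br)c2)o1`: 7500 nM
compound 3, `Clc1cccc(Cl)c1Cc1nnc(Nc2ccc(COCc3cccnc3)cc2)o1`: 81000 nM

All three numbers come from an ADME assay on MT2 cells (Homo sapiens) for cytotoxicity, read by MTT assay; on this read-out lower numbers stand for higher toxicity in this test and higher numbers for lower toxicity in this test. Compound 1 stands second highest of the three. Its nearest neighbour is compound 2; the two values lie within the usual scatter of each other, so no order between compound 1 and compound 2 is claimed. The furthest is compound 3, whose value is higher than that of compound 1 by more than the scatter; compound 3 differs from compound 1 in several places at once, so no single change carries that gap.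

Compound 4 is `OCCc1ccc(Nc2ncc(Cc3c(F)cccc3F)o2)cc1`, not yet measured in this assay. Against compound 1 the change is hydrogen in place of pyridin-4-yl on an oxygen on a saturated carbon. Going by the values given here, no measured pair differs by this change alone, so the size of the step is a guess. All three measured compounds sit at the weakly toxic end of this assay, and the change removes a pyridin-4-yl without touching the shared core, so a small step is expected, if anything toward a higher number and probably within the scatter. The expected step is a 1.4-fold higher number from compound 1 to compound 4 (0.13 log units; within the scatter). Compound 4 is estimated at 15000 nM, with a range from 6000 nM to 40000 nM.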

Compound 4, half-maximal cytotoxic concentration: 35000 nM
For compound 4 the middle estimate is 2.3-fold (0.37 log units) below the measured one; low and high end bracket the measured number.
By their numbers in this assay, from the lowest: compounds 2 and 1 (each within the scatter of the next); then compound 4; then compound 3.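

In this assay, replacing the pyridin-4-yl on the oxygen with hydrogen, which turns the 2-((pyridin-4-yl)oxy)ethyl group into 2-hydroxyethyl, gives a 3.2-fold higher number from compound 1 to compound 4 (0.50 log units; beyond the scatter). Going by these compounds alone, this is the first change that can be read at a single place, and the step, though modest, lies beyond the scatter, so this position on the shared core is not silent in this test. The direction is toward lower toxicity in this test, with the core and the 2,6-difluorobenzyl-bearing side of compound 1 left as they are; nothing at hand bears on why the step occurs.

The compounds shown leave open whether the step follows from the loss of the pyridin-4-yl ring or from the free hydroxy, a question that a methyl ether or a phenyl ether on the same oxygen would separate. Also open, from the compounds shown here alone, is how far the position tolerates other ends, such as a primary amine, a carboxylic acid or a longer chain ending in hydroxy, and whether the step holds on another core.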